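The source may report more compounds than this note shows. Statements on the series, on what has been measured and on what is new or still open speak of the compounds shown alone.

Compound 1 `Cn1cc(/C=C/C(=O)NS(=O)(=O)c2cc(F)c(F)cc2F)c2c(Oc3ccc4ccccc4c3)cccc21` gives 91.2% in an ADME assay on microsomes from liver (Homo sapiens) for metabolic stability, with a stated time of 30 min, tested at 5 uM; a higher number here means that more of the compound is left, a lower number that less of the compound is left. Compound 2 `Cn1cc(/C=C/C(=O)NS(=O)(=O)c2cccc(Cl)c2)c2c(Oc3ccc4ccccc4c3)cccc21` gives 79% in this assay. Compound 3 `Cn1cc(/C=C/C(=O)NS(=O)(=O)c2ccc(F)c(F)c2)c2c(Oc3ccc(Cl)cc3F)cccc21` gives 113% in this assay.

Among these three numbers compound 1 stands second highest: compound 2 sits nearest, with a number 12.2 percentage points lower from compound 1 to compound 2 (beyond the scatter), while compound 3 lies furthest away, its value being beyond the scatter above that of compound 1.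

Compound 4 `Cn1cc(/C=C/C(=O)NS(=O)(=O)c2cc(F)c(F)cc2F)c2c(Oc3ccc(Cl)cc3Cl)cccc21` has not yet been measured. It differs from compound 1 in one place: 2,4-dichlorophenyl in place of naphthalen-2-yl on an oxygen on an aromatic ring. Among the measured compounds shown here, none of the measured steps touches this part of the shared core. For the measured compounds named here, the only single-point step, from compound 1 to compound 2, changes the group on the sulfonyl sulfur and is modest in size. Going by the values given here, compound 3 carries a halogenated phenoxy group in place of the (naphthalen-2-yl)oxy group, but it also differs from compound 1 on the sulfonyl sulfur, so its value shows only that a compound with a halophenoxy group can reach a high number in this assay.

Among the compounds with values here, with no direct step to lean on, the expectation is that compound 4 moves little from compound 1, at most slightly upward, which is a number 4.8 percentage points higher from compound 1 to compound 4 (within the scatter). Compound 4 is therefore estimated at 96%, with a range from 76% to 116%.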

Compound 4, percent of the compound remaining: 74.7%
Compound 4: middle estimate off by 21.3 percentage points, on the high side; the measured number lies below the stated range.
By their numbers in this assay, from the lowest: compounds 4 and 2 (each within the scatter of the next); then compound 1; then compound 3.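

Among the compounds shown here, the step gives the first direct reading at this position: with the 2,4,5-trifluorophenyl group held on the sulfonyl sulfur in this assay, going from (naphthalen-2-yl)oxy to 2,4-dichlorophenoxy yields a number 16.5 percentage points lower from compound 1 to compound 4 (beyond the scatter). The group on an oxygen on an aromatic ring therefore matters in this assay, just as the group on the sulfonyl sulfur does in a number 12.2 percentage points lower from compound 1 to compound 2 (beyond the scatter), and each of these steps lies beyond the scatter. None of the information available offers an explanation for the new step.

This single replacement changes the ring count and brings in two chlorine atoms at once, so the compounds shown do not separate these two changes, and an unsubstituted phenyl on the same oxygen would help to tell them apart. Also open, from the compounds shown here alone, is whether the same replacement gives a step of similar size with another group on the sulfonyl sulfur, and how a phenoxy group carrying an amine or a carboxylic acid would read in this assay.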